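This account rests on a few compounds, and the source may have more. Where it says the series, first, only, none or still open, it means among the compounds named here.

Measured so far:
- compound 1, `CC(C)(C)Cc1c(Br)sc(N)c1C(=O)c1cccc(C(F)(F)F)c1`: 1%
- compound 2, `CC(C)(C)Cc1c(-c2ccccc2)sc(N)c1C(=O)c1cccc(Cl)c1`: 2%

Both compounds were tested in an assay on CHO cells for displacement of a labelled ligand from adenosine receptor A1 (Homo sapiens), read by scintillation counting, tested at 10 uM; a lower number here means less inhibition, a higher number more inhibition at the concentration tested (going by the name of the read-out). Compound 1 gives 1% there, and compound 2 gives 2%. On the numbers shown, compound 2 has the higher of the two readings, but the gap to compound 1 lies within the usual scatter of such measurements, so the two cannot be told apart, and neither shows meaningful inhibition at the concentration tested. Within the data shown here, the two compounds differ in two places at once, so no single step between them can be read off.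

The next compound is compound 3, `CC(C)(C)Cc1c(-c2ccccc2)sc(N)c1C(=O)c1cccc(C(F)(F)F)c1`, which is compound 2 with one change: trifluoromethyl in place of chloro on an aromatic carbon. Compound 1 already carries a trifluoromethyl at that same position and reads no differently from compound 2, so there is no reason in the data to expect the change to move the reading beyond the scatter in either direction. The step from compound 2 to compound 3 is therefore expected to be no change at the digits printed from compound 2 to compound 3 (within the scatter), essentially none. For compound 3 in this assay the estimate is 2%, with a range from -8% to 12%.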

Compound 3, a percentage reported as inhibition, at one concentration (the size of the read-out at that concentration, not a potency): 1%
For compound 3 the middle estimate is 1 percentage points above the measured one; the range from low to high includes it.
By their numbers in this assay, from the lowest: compounds 1, 3 and 2 (each within the scatter of the next).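

Among these compounds, compound 3 provides the first comparisons in which only one place differs. In this assay the swap of chloro for trifluoromethyl on an aromatic carbon, meta to a large group, gives a number 1 percentage points lower from compound 2 to compound 3 (within the scatter) and phenyl in place of bromo on an aromatic carbon gives no change at the digits printed from compound 1 to compound 3 (within the scatter) so neither single change can be told from the scatter. This shows that a group of 1 heavy atom and one of 4 heavy atoms can stand at the meta place without the reading leaving the scatter, but all three readings lie so close to nothing that a real effect of either change could not show here. No measurement is available that would explain these readings.

From the compounds shown here alone, it remains open whether another group at these two places, such as an amine, a carboxylic acid or a longer chain, would bring clear inhibition at the concentration tested. Going by these compounds, it is also open whether chloro and trifluoromethyl, or bromo and phenyl, would still read alike on a compound with clear inhibition in this assay to begin with.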